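This account rests on a few compounds, and the source may have more. Where it says the series, first, only, none or still open, it means among the compounds named here.

Measured so far in a functional assay on HeLa S3 cells (Homo sapiens) for antiproliferative activity, read by XTT assay, with a stated time of 72 h; on this read-out higher numbers stand for weaker inhibition and lower numbers for stronger inhibition:

- compound 1, `CN(C)c1ncnc2c1c(-c1ccsc1)cn2[C@@H]1O[C@H](CO)[C@@H](O)[C@H]1O`. In this assay compound 1 gives > 15000 nM, a limit of the assay and not a number.
- compound 2, `Cc1nc(N)c2c(-c3ccccc3)cn([C@@H]3O[C@H](CO)[C@@H](O)[C@H]3O)c2n1`. In this assay compound 2 gives > 20000 nM, again a limit rather than a number.
- compound 3, `COc1nc(N)nc2c1c(-c1ccsc1)cn2[C@@H]1O[C@H](CO)[C@@H](O)[C@H]1O`. In this assay compound 3 gives > 20000 nM, again only a limit.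

Compound 2 thus stands at a limit, and the two other values shown are limits as well: the limit of > 15000 nM in this assay, at which 1 of the 3 values shown sits, and (the limit of > 20000 nM in this assay, at which 2 of the 3 values shown sit). Among the measured compounds shown here, none of the three compounds differ from one another in a single place, so no measured step can be read off, and none of the values allows an ordering of the compounds.

Compound 4, `Cc1nc(N)c2c(-c3ccco3)cn([C@@H]3O[C@H](CO)[C@@H](O)[C@H]3O)c2n1`, differs from compound 2 in one place: furan-2-yl in place of phenyl on an aromatic carbon. For the measured compounds named here, with every measured value of the series sitting at a limit and no measured step to lean on, no movement beyond the scatter is expected; the step from compound 2 to compound 4 is estimated as a number no higher from compound 2 to compound 4 (the limit leaves the size open). In this assay compound 4 is expected to give about 20000 nM, within a range of 8000 nM to 60000 nM, most likely reported once more as a limit.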

Compound 4, half-maximal inhibitory concentration: > 20000 nM
Compound 4 ended at the assay's limit; the forecaster's own chance of this, stated with the estimate: 80%; the middle value sits exactly at the limit.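

Compound 2 and compound 4 both stand at a limit of the assay, so no step can be read for furan-2-yl in place of phenyl on an aromatic carbon. The compounds shown leave open where the true value of any of them lies, and whether this exchange changes antiproliferative activity at all.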